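Fluorine on the benzyl ring of an inactive series

The source may hold more compounds than are shown below. What is called first, only, known or untested is meant among the compounds shown, and "the series" means these compounds.

Compound 1 `CN(CC(=O)N1CCN(c2ccc(F)cc2)CC1)C(=O)c1ccc(S(C)(=O)=O)c([N+](=O)[O-])c1` gives in an assay on isolated protein for inhibition of vitamin D3 receptor (Homo sapiens), read by fluorescence polarization (on this read-out higher numbers stand for weaker inhibition and lower numbers for stronger inhibition), only a limit, > 60000 nM.
Compound 2 `CN(Cc1ccccc1)C(=O)CNC(=O)c1ccc(S(C)(=O)=O)c([N+](=O)[O-])c1` gives in this assay only a limit, > 60000 nM.
Compound 3 `CN(CC(=O)N1CCN(c2ccccc2)CC1)C(=O)c1ccc(S(C)(=O)=O)c([N+](=O)[O-])c1` gives in this assay only a limit, > 60000 nM.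

Compound 1 differs from compound 3 by fluoro in place of hydrogen on an aromatic carbon. The resulting step that the two limits leave unreadable from compound 3 to compound 1 cannot be read, because both values sit at the limit of > 60000 nM in this assay, at which 3 of the 3 values shown sit. Compound 4 `CN(Cc1cccc(F)c1)C(=O)CNC(=O)c1ccc(S(C)(=O)=O)c([N+](=O)[O-])c1` is not yet measured and differs from compound 2 by fluoro in place of hydrogen on an aromatic carbon. The cores of compound 2 and compound 3 differ in a way not broken down here. The two places also differ: para to a large group in the measured pair, meta to a large group in the new pair, so this is the same kind of change, not the same one. The step from compound 2 is expected to be a step that the limit leaves unreadable from compound 2 to compound 4, resting on compound 2 giving only a limit, > 60000 nM. Compound 4 is therefore expected to give 100000 nM, most likely again as a limit.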

Compound 4, half-maximal inhibitory concentration: > 60000 nM
Compound 4 ended at the assay's limit (the forecaster's own chance of this, stated with the estimate: 85%); the middle value lies beyond the limit too.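

No size can be read for the fluoro step between compound 2 and compound 4, because both sit at the same limit: the limit of > 60000 nM in this assay, at which 4 of the 4 values shown sit.

The compounds shown leave open whether fluoro changes inhibition at all, since none gives a value inside the assay's range.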